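A few compounds are considered here, and "the series" means these few. Any claim that something is new, unique, unknown or untested is made for them only; others in the source may bear on it.

Measured so far in a functional assay on A2780 cells (Homo sapiens) for antiproliferative activity, read by fluorescence, with a stated time of 72 h; on this read-out higher numbers stand for weaker inhibition and lower numbers for stronger inhibition:
- compound 1 `CN1CCC(C(=O)N2Cc3c(NC(=O)c4cccs4)n[nH]c3C2(C)C)CC1`: 30 nM
- compound 2 `CN1CCC(C(=O)N2Cc3c(NC(=O)c4ccc(F)c(F)c4)n[nH]c3C2(C)C)CC1`: 100 nM
- compound 3 `CC(C)(C)C(=O)N1Cc2c(NC(=O)c3ccncc3)n[nH]c2C1(C)C`: 110 nM

Compound 3 lies within the usual scatter of compound 2, and its number is higher than that of compound 1, a gap beyond the scatter. Compound 4 `CN1CCC(C(=O)N2Cc3c(NC(=O)c4ccncc4)n[nH]c3C2(C)C)CC1` keeps the rest of compound 3 and makes one change: 1-methylpiperidin-4-yl in place of tert-butyl on a carbonyl carbon, (1-methylpiperidin-4-yl in place of tert-butyl on a carbonyl carbon).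

For the measured compounds named here, no measured step makes this change directly. Going by the values given here, the only step available is a 3.3-fold higher number from compound 1 to compound 2 (0.52 log units; beyond the scatter), and it concerns the other acyl group, so it shows only that a change at that end can move the number modestly. Compound 1 and compound 2 both carry the entering 1-methylpiperidin-4-yl group, and their values span a modest range that takes in the value of compound 3. Nothing here therefore points to a large shift, and in this assay no step beyond the scatter is expected, with at most a slight lean towards a lower number. The estimated step is a 1.4-fold lower number from compound 3 to compound 4 (0.14 log units; within the scatter). Compound 4 is expected at 80 nM, with an estimated range from 25 nM to 250 nM.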

Compound 4, half-maximal inhibitory concentration in the A2780 assay: 500 nM
Compound 4: middle estimate off by 6.3-fold (0.80 log units), on the low side; measured number outside the range, above it.
By their numbers in the A2780 assay, from the lowest: compound 1; then compounds 2 and 3 (each within the scatter of the next); then compound 4.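

For the compounds shown here, in the A2780 assay, a 4.5-fold higher number from compound 3 to compound 4 (0.66 log units; beyond the scatter) gives the first direct reading of this change on a carbonyl carbon: with pyridin-4-yl kept on the other carbonyl, 1-methylpiperidin-4-yl gives weaker inhibition than tert-butyl, a shift the earlier compounds could not show. With 1-methylpiperidin-4-yl held fixed, the other acyl group also matters, since pyridin-4-yl gives weaker inhibition than 3,4-difluorophenyl in a 5.0-fold higher number from compound 2 to compound 4 (0.70 log units; beyond the scatter) and than thiophen-2-yl in a 17-fold higher number from compound 1 to compound 4 (1.22 log units; beyond the scatter), the last being a large step and the biggest seen here. In a physicochemical assay for solubility, at pH 7 (a higher number here means a more soluble compound, a lower number a less soluble compound), compound 4 gives > 225000 nM, which is a limit of the assay and not a number: the limit of > 225000 nM in the physicochemical assay, at which 1 of the 2 values shown sits.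

The compounds shown leave open whether the step from tert-butyl to 1-methylpiperidin-4-yl would hold with thiophen-2-yl or 3,4-difluorophenyl on the other carbonyl, and how a piperidin-4-yl group without the methyl or a morpholine ring would read in its place. On these data alone, in the physicochemical assay compound 3 gives 205000 nM, and how far compound 4 truly lies from it also stays open.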